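The source may hold more compounds than are shown below. What is called first, only, known or untested is meant among the compounds shown, and "the series" means these compounds.

Compound 1, `CCCCC[Se]c1nc(N)c2ccccc2n1`, gives 59500 nM in a functional assay on MCF7 cells (Homo sapiens) for cytotoxicity, read by MTT assay, with a stated time of 72 h; on this read-out higher numbers stand for weaker inhibition of growth and lower numbers for stronger inhibition of growth.
Compound 3, `[SeH]c1nc([SeH])c2cccnc2n1`, gives 46100 nM.
Compound 2, `C[Se]c1nc(N)c2ccccc2n1`, gives > 100000 nM, which is a limit of this assay and not a number (the limit of > 100000 nM in this assay, at which 1 of the 3 values shown sits).

Among the two numbers, compound 1 has the higher one, with compound 3 nearest; that gap lies within the scatter, so the two cannot be ranked. The unmeasured compound 4, `CCCCC[Se]c1nc([Se]CCCCC)c2ccccc2n1`, differs from compound 1 in one place: a group of 6 heavy atoms (5 carbon, 1 selenium; no ring) in place of one nitrogen atom, on an aromatic carbon. Among the compounds with values here, the only measured step that touches a chain on selenium is an at least 1.6-fold higher number from compound 1 to compound 2 (0.22 log units; that floor lies within the scatter), and its floor lies within the scatter. That step alters the chain itself and keeps the amino group, so it speaks only indirectly to the exchange of the amino group for a second selenium-bearing chain in compound 4. Within the data shown here, the data hold no measured step of that kind. The expectation is therefore no step beyond the scatter in this assay, with a wide range to cover the uncertainty. The estimated step is a 1.1-fold lower number from compound 1 to compound 4 (0.03 log units; within the scatter). Compound 4 is expected to give about 55000 nM, somewhere between 15000 nM and 200000 nM.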

Compound 4, concentration for total growth inhibition: 95100 nM
The estimate for compound 4 lay 1.7-fold (0.24 log units) below the measured number; measured number inside the range.
By their numbers in this assay, from the lowest: compounds 3, 1 and 4 (each within the scatter of the next, the first and the last beyond it). At a limit, above all of these: compound 2.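

Within the data shown here, this is the first measured change at the aromatic carbon next to the ring nitrogen, where compound 1 carries its amino group. Replacing that amino group with a group of 6 heavy atoms (5 carbon, 1 selenium; no ring) brings a 1.6-fold higher number from compound 1 to compound 4 (0.20 log units; within the scatter) in this assay, so in this assay a far larger group without the hydrogen-bond donor and acceptor of the amino group leaves a step that cannot be told from the scatter, and the amino group is not shown to be needed here. No measured property shown here accounts for the size of this step.

On these data alone, whether a different kind of group on this carbon, such as a hydroxyl group or a methylamine, would move the number beyond the scatter remains open. Also open, as far as these compounds go, is whether a longer chain on selenium, or a ring in place of the chain, would change growth inhibition when the amino group is kept and when it is replaced.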